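The source may report more compounds than this note shows. Statements on the series, on what has been measured and on what is new or still open speak of the compounds shown alone.

Measured so far in a functional assay on HL-60 cells (Homo sapiens) for inhibition, read by CCK-8 assay, with a stated time of 48 h, tested at 20 uM; on this read-out higher numbers stand for more inhibition of growth at the one concentration tested and lower numbers for less inhibition of growth:
- compound 1 `COc1ccc(Cc2nnc(NC(=O)/C(C#N)=C/c3ccccc3OS(=O)(=O)c3ccc([N+](=O)[O-])cc3)s2)cc1`: 51%
- compound 2 `COc1ccc(Cc2nnc(NC(=O)/C(C#N)=C/c3ccccc3OS(=O)(=O)c3ccc(F)cc3)s2)cc1`: 25%

In this assay, compound 1 gives 51%, the higher of the two numbers. Compound 3 `N#C/C(=C\c1ccccc1OS(=O)(=O)c1ccc([N+](=O)[O-])cc1)C(=O)Nc1nnc(Cc2ccc(F)cc2)s1` keeps the core of compound 1 and changes one group: fluoro in place of methoxy on an aromatic carbon. This is fluoro in place of methoxy on an aromatic carbon. For the measured compounds named here, the only measured step, a number 26 percentage points lower from compound 1 to compound 2 (beyond the scatter), is fluoro in place of nitro elsewhere in the molecule. Going by the values given here, it shows that one swap can move this number, but no measured step tests the methoxy group. The expected step is a number 8 percentage points lower from compound 1 to compound 3 (within the scatter), smaller than the measured one, and its direction is uncertain. For compound 3 the estimated value is 43%, with an expected range of 23% to 63%.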

Compound 3, percent growth inhibition at one concentration: 18%
Compound 3: middle estimate off by 25 percentage points, on the high side; the whole stated range lies above it.
By their numbers in this assay, from the lowest: compounds 3 and 2 (each within the scatter of the next); then compound 1.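

Replacing 4-methoxybenzyl with 4-fluorobenzyl gives a number 33 percentage points lower from compound 1 to compound 3 (beyond the scatter) in this assay and so shows that this position, untested by the earlier step, can change the read-out. Compound 1 now stands clearly above both single-swap partners, with a change at either of two places lowering the number. Nothing measured here accounts for this drop.

The compounds shown leave open whether methoxy itself supports growth inhibition or fluoro reduces it. A hydroxyl, an amine or a plain hydrogen at the same place would help separate these two readings.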